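The source may hold more compounds than are shown below. What is called first, only, known or untested is meant among the compounds shown, and "the series" means these compounds.

Two members of the series, which share one core, have been measured in a functional assay on COR-L23 cells (Homo sapiens) for antiproliferative activity, read by CellTiter-Glo, with a stated time of 4 days; on this read-out lower numbers stand for stronger inhibition and higher numbers for weaker inhibition. Compound 1 `O=C(Nc1ccc(CN2C(=O)c3ccccc3C2=O)cc1)[C@H]1C[C@@H]1c1cccnc1` gives 35 nM in this assay. Compound 2 `CCC(=O)N[C@@H](C)c1ccc(NC(=O)[C@H]2C[C@@H]2c2cccnc2)cc1` gives 22 nM in this assay, the lower of the two numbers; the gap to compound 1 lies within the scatter, so the two compounds are not distinguished by these values. Compound 3 `C[C@H](NC(=O)c1ncccn1)c1ccc(NC(=O)[C@H]2C[C@@H]2c2cccnc2)cc1` has not yet been measured in this assay. It differs from compound 2 in one place: pyrimidin-2-yl in place of ethyl on a carbonyl carbon. For the measured compounds named here, no step between measured compounds covers a change of this kind, so the expectation rests only on compound 2 and its value 22 nM. The step from compound 2 to compound 3 is expected to be a 1.1-fold higher number from compound 2 to compound 3 (0.06 log units; within the scatter), with no clear direction beyond the scatter. Compound 3 is therefore estimated at 25 nM, within a range from 8 nM to 80 nM.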

Compound 3, half-maximal inhibitory concentration in the COR-L23 assay: 17 nM
Compound 3: the middle estimate sits 1.5-fold (0.17 log units) above what was measured; low and high end bracket the measured number.
By their numbers in the COR-L23 assay, from the lowest: compounds 3, 2 and 1 (each within the scatter of the next, the first and the last beyond it).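

In the COR-L23 assay, pyrimidin-2-yl in place of ethyl on a carbonyl carbon gives a 1.3-fold lower number from compound 2 to compound 3 (0.11 log units; within the scatter), so at this position a six-membered aromatic ring stands in for a small open chain with no change that can be told from the scatter. In a physicochemical assay for solubility, at pH 6.8 (a higher number here means a more soluble compound, a lower number a less soluble compound), where compound 2 gives 54000 nM and compound 3 gives 27000 nM, the same replacement gives a 2.0-fold lower number from compound 2 to compound 3 (0.30 log units; within the scatter), so neither read-out separates the two compounds. Nothing measured here offers an explanation for these results.

What the compounds shown leave open is how a phenyl ring, which carries no ring nitrogen, would compare with pyrimidin-2-yl on this carbonyl carbon. They also leave open how an amine, a carboxylic acid or a longer alkyl chain would read out at the same place.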